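The compounds below may be only part of what the source reports. "The series", "measured", "known", "first", "only" and "open" are said of these compounds alone.

Compound 1, `O=C(O)c1csc(-n2nc(-c3ccccc3)c3c2CCCCC3)n1`, gives in an assay on isolated protein for antagonist activity at prostaglandin E2 receptor EP1 subtype (Homo sapiens), read by reporter gene assay (on this read-out lower numbers stand for stronger inhibition and higher numbers for weaker inhibition), a value of 1000 nM.
Compound 2, `O=C(O)c1csc(-n2nc(-c3ccccc3)c3cc(F)ccc32)n1`, gives in this assay a value of 80 nM.
Compound 3, `O=C(O)c1csc(-n2nc(-c3ccccc3)c3ccc(F)cc32)n1`, gives in this assay a value of 2 nM.

All three share the same core and differ only in the ring fused to the five-membered ring and in where a fluoro sits on it. Compound 3 stands at the lowest number of the three in this assay, and therefore as the strongest inhibitor on this read-out; its nearest neighbour is compound 2, and the gap between them is well beyond the scatter, as is the larger gap to compound 1.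

The next compound keeps the fused aromatic ring of compound 3 and changes only the substituent on it. Compound 4, `O=C(O)c1csc(-n2nc(-c3ccccc3)c3ccc(O)cc32)n1`, differs from compound 3 by hydroxy in place of fluoro on an aromatic carbon. Going by the values given here, no pair among the measured compounds shows what such an exchange does, so the expectation rests on compound 3 alone and carries wide uncertainty. A moderate rise in the number of this assay, that is a somewhat weaker inhibition, is expected for compound 4, though a result within the scatter of compound 3 is also possible. The estimated step from compound 3 to compound 4 is a 5.0-fold higher number from compound 3 to compound 4 (0.70 log units; beyond the scatter). Compound 4 is accordingly estimated at 10 nM, with a range from 2 nM to 60 nM.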

Compound 4, half-maximal inhibitory concentration: 140 nM
For compound 4 the middle estimate is 14-fold (1.15 log units) below the measured one, outside the stated range (above it).
By their numbers in this assay, from the lowest: compound 3; then compounds 2 and 4 (each within the scatter of the next); then compound 1.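

In this assay, exchanging fluoro for hydroxy on this aromatic carbon gives a 70-fold higher number from compound 3 to compound 4 (1.85 log units; beyond the scatter), a large loss of inhibition from a change of a single heavy atom. Going by these compounds alone, the count of heavy atoms stays the same, so inhibition at this place clearly depends on which atom is attached and not just on how many atoms the group contains, a point that the earlier compounds could not show. The exchange also adds a hydrogen-bond donor and a hydrogen-bond acceptor, but nothing here links either of them to the result, and no independent measurement explains why inhibition falls so far.

As far as these compounds go, because this place is compared through fluoro and hydroxy alone, it remains open whether a methoxy group, a chlorine atom or an amine would keep inhibition close to that of compound 3 or lose it as compound 4 does. From the compounds shown here alone, it is also open whether the same exchange would bring a step of similar size at the place that carries the fluoro in compound 2.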